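A few compounds are considered here, and "the series" means these few. Any claim that something is new, unique, unknown or untested is made for them only; others in the source may bear on it.

Of the compounds shown here, three built on one shared core have been measured in a physicochemical assay for solubility, using the shake flask method, in simulated intestinal fluid, measured as kinetic solubility, with a stated time of 20 h, at pH 6.5; on this read-out lower numbers stand for lower solubility and higher numbers for higher solubility. Compound 2 `FC(F)(F)c1ccc(Nc2cc3[nH]c(C4CCCC4)nc3cn2)nc1` gives 85000 nM, and compound 3 `FC1(F)CCC(c2nc3cnc(Nc4ccc(C(F)(F)F)cn4)cc3[nH]2)C1` gives 163000 nM. Compound 1 `FC(F)(F)c1ccc(Nc2cc3[nH]c(-c4cccc(C(F)(F)F)c4)nc3cn2)nc1` gives >= 50000 nM, which is a limit of the assay and not a number. Compound 3 therefore sits within the scatter of compound 2 and cannot be ranked against compound 1. The comparisons with compound 1 add no size to work with: there is a step that the limit leaves unreadable from compound 1 to compound 2, and likewise a step that the limit leaves unreadable from compound 1 to compound 3.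

Compound 4 `FC(F)(F)c1ccc(Nc2cc3[nH]c(C4CCOCC4)nc3cn2)nc1` differs from compound 3 in that same place: oxan-4-yl stands in place of 3,3-difluorocyclopentyl on an aromatic carbon of a five-membered aromatic ring, between two ring nitrogen atoms (oxan-4-yl in place of 3,3-difluorocyclopentyl on an aromatic carbon). Among the compounds with values here, the one readable step at this place is a 1.9-fold higher number from compound 2 to compound 3 (0.28 log units; within the scatter), and it stays within the scatter. Within the data shown here, no measured compound carries a ring with a hetero atom here, so that single step is a thin guide. On this evidence, no shift beyond the scatter is expected in this assay. The expected change is a 1.3-fold lower number from compound 3 to compound 4 (0.10 log units; within the scatter). For compound 4 the estimate is 130000 nM, with an expected range from 50000 nM to 340000 nM.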

Compound 4, solubility: 168000 nM
For compound 4 the middle estimate is 1.3-fold (0.11 log units) below the measured one; low and high end bracket the measured number.
By their numbers in this assay, from the lowest: compounds 2, 3 and 4 (each within the scatter of the next).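

In this assay, within the data shown here, this position now carries a non-aromatic ring with a hetero atom, and a hydrogen-bond acceptor, for the first time: oxan-4-yl in place of 3,3-difluorocyclopentyl gives a 1.0-fold higher number from compound 3 to compound 4 (0.01 log units; within the scatter). Set against plain cyclopentyl, the same oxan-4-yl gives a 2.0-fold higher number from compound 2 to compound 4 (0.30 log units; within the scatter), so among the three non-aromatic rings shown, exchanging carbon-only rings for a ring with oxygen, or adding two fluorine atoms, moves no number beyond the scatter. Compound 1 gives a limit and not a number, so its steps to the other compounds cannot be read: the limit of >= 50000 nM in this assay, at which 1 of the 4 values shown sits.

The compounds shown leave open whether the number at this place would move beyond the scatter with an amine or a carboxylic acid on the ring, or with a longer open chain in place of the ring. They also leave open whether any aromatic ring at this place, on an aromatic carbon between two ring nitrogen atoms, would give a number that can be compared directly with those of the non-aromatic rings.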